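Aryl exchange on the amide-type nitrogen: compound 3

The compounds below may be only part of what the source reports. "The series", "measured", "known", "first", "only" and "open" are said of these compounds alone.

Measured so far:
Compound 1, `CCN(CC)CCn1cnnc1-c1cc(Oc2ccc(NC(=O)Nc3cccc(C(F)(F)F)c3)cc2F)ccn1`, in a functional assay on HT-29 cells (Homo sapiens) for antiproliferative activity, read by MTT assay, with a stated time of 72 h; a higher number here means a weaker inhibitor, a lower number a stronger inhibitor: 630 nM
Compound 2, `CCN(CC)CCn1cnnc1-c1cc(Oc2ccc(NC(=O)Nc3ccc(F)c(Cl)c3)cc2F)ccn1`, in this assay: 500 nM

Compound 2 has the lowest of the two numbers, with compound 1 nearest to it; the step of a 1.3-fold lower number from compound 1 to compound 2 (0.10 log units; within the scatter) lies within the scatter, so the two compounds cannot be separated on these numbers. That single step is an exchange of one aryl ring for another on the amide-type nitrogen, and it left the read-out essentially unchanged.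

Compound 3, `CCN(CC)CCn1cnnc1-c1cc(Oc2ccc(NC(=O)Nc3ccc(Cl)cc3Cl)cc2F)ccn1`, is not yet measured. It differs from compound 2 by 2,4-dichlorophenyl in place of 3-chloro-4-fluorophenyl on an amide-type nitrogen. Within the data shown here, the only measured step that bears on this change is a 1.3-fold lower number from compound 1 to compound 2 (0.10 log units; within the scatter), the same kind of aryl-for-aryl swap at the same place, which stayed within the scatter. On that basis no step beyond the scatter is expected from compound 2 to compound 3, in either direction, though one comparison is a thin footing and the new ring differs from both rings seen so far. For compound 3 the expected value in this assay is 550 nM, range 250 nM to 1300 nM, which corresponds to an expected step of a 1.1-fold higher number from compound 2 to compound 3 (0.04 log units; within the scatter).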

Compound 3, half-maximal inhibitory concentration: 3590 nM
Compound 3: middle estimate off by 6.5-fold (0.81 log units), on the low side; the measured number lies above the stated range.
By their numbers in this assay, from the lowest: compounds 2 and 1 (each within the scatter of the next); then compound 3.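

In this assay this place on the amide-type nitrogen proves sensitive to the choice of aryl ring: 2,4-dichlorophenyl gives a 7.2-fold higher number from compound 2 to compound 3 (0.86 log units; beyond the scatter) and a 5.7-fold higher number from compound 1 to compound 3 (0.76 log units; beyond the scatter) in contrast to the earlier exchange, which stayed within the scatter. The tolerance seen for 3-(trifluoromethyl)phenyl and 3-chloro-4-fluorophenyl therefore does not extend to every halogen-bearing phenyl ring at this place, and the series now holds one aryl exchange that can be told apart from the scatter. No measurement in hand accounts for the size of these steps.

The three rings do not show which of the two chlorines of 2,4-dichlorophenyl goes with the higher number, as no ring carrying only one of them appears among the compounds shown. Also open, going by these compounds, is how a phenyl ring bearing a methoxy group, a nitrile or an amine, or a saturated cyclohexyl ring, would read on this amide-type nitrogen with the core unchanged.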